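Para halogen swap on the keto-acid thioether series

A few compounds are considered here, and "the series" means these few. Any claim that something is new, unique, unknown or untested is made for them only; others in the source may bear on it.

Compound 2 `O=C(O)CSC(CC(=O)c1ccc(F)cc1)C(=O)O` is the starting point. In a functional assay on HeLa cells (Homo sapiens) (a higher number here means a weaker inhibitor, a lower number a stronger inhibitor), compound 2 gives 20700 nM. Among the compounds with values here, the only other measured member, compound 1 `Cc1ccc(C(=O)CC(SCC(=O)O)C(=O)O)cc1`, gives 17300 nM in this assay, and the two values sit within the scatter of each other, so no order between them can be read. Within the data shown here, the one measured step, a 1.2-fold higher number from compound 1 to compound 2 (0.08 log units; within the scatter), shows that exchanging the substituent at the same aromatic position did not move this assay beyond its noise.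

Compound 3 `O=C(O)CSC(CC(=O)c1ccc(Cl)cc1)C(=O)O` differs from compound 2 by chloro in place of fluoro on an aromatic carbon. Among the measured compounds shown here, this is a second exchange at the same position, and the only step that bears on it is a 1.2-fold higher number from compound 1 to compound 2 (0.08 log units; within the scatter), which was flat. On that basis the expected step for this assay is a 1.0-fold lower number from compound 2 to compound 3 (0.01 log units; within the scatter), that is, no change beyond the scatter in either direction. Compound 3 is therefore estimated at 20000 nM in this assay, with a range from 10000 nM to 40000 nM, pending the measurement.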

Compound 3, half-maximal inhibitory concentration: 17300 nM
Compound 3: middle estimate off by 1.2-fold (0.06 log units), on the high side; the range from low to high includes it.
By their numbers in this assay, from the lowest: compounds 1, 3 and 2 (each within the scatter of the next).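

With chloro in place of fluoro, the step in this assay is a 1.2-fold lower number from compound 2 to compound 3 (0.08 log units; within the scatter) and stays flat, and with chloro in place of methyl it is no change at the digits printed from compound 1 to compound 3 (within the scatter) at the same position. The aromatic carbon para to a large group has now carried methyl, fluoro and chloro, and all three pairs lie within the scatter, so no order among compound 1, compound 2 and compound 3 can be read and the flat reading now rests on three substituents instead of two. Nothing measured alongside these values accounts for the flat outcome.

Still open, from the compounds shown here alone, is whether any other kind of group on this aromatic carbon, such as an amine, a methoxy group or a carboxylic acid, would move the number in this assay beyond the scatter. Within the data shown here, also open is whether changes elsewhere on the shared core, such as a longer chain on the sulfur in place of the one carried by compound 1, compound 2 and compound 3, would matter more than this exchange of substituents.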